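The source may hold more compounds than are shown below. What is called first, only, known or untested is meant among the compounds shown, and "the series" means these compounds.

Measured so far:
compound 1 `O=C(O)CCCSCCN1C(=O)OC[C@@H]1/C=C/[C@@H](O)Cc1ccccc1`: 4.2 nM
compound 2 `O=C(O)CCCSCCN1C(=O)SC[C@@H]1/C=C/[C@@H](O)Cc1ccccc1`: 0.65 nM

In an assay on CHO cells for displacement of a labelled ligand from prostaglandin E2 receptor EP4 subtype (Mus musculus), read by scintillation counting, with a stated time of 60 min (a lower number here means a stronger inhibitor, a higher number a weaker inhibitor), compound 2 gives the lower of the two numbers; compound 1 gives the higher one, by a margin beyond the scatter. Compound 3 `CCCc1cccc(C[C@H](O)/C=C/[C@H]2CSC(=O)N2CCSCCCC(=O)O)c1` differs from compound 2 by a single change, (propyl in place of hydrogen on an aromatic carbon), on an aromatic carbon of the six-membered aromatic ring of carbon only, meta to a large group. For the measured compounds named here, no measured pair shows this change, so no step size can be read off. For compound 3 the expected step of a 1.3-fold lower number from compound 2 to compound 3 (0.11 log units; within the scatter) is within the scatter, leaning if anything to a lower number. Compound 3 is thus expected to give 0.5 nM, within 0.15 nM to 2 nM.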

Compound 3, inhibition constant: 0.98 nM
Beside the measured number, compound 3's estimate is 2.0-fold (0.29 log units) below it, within the range that was stated.
By their numbers in this assay, from the lowest: compounds 2 and 3 (each within the scatter of the next); then compound 1.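

In this assay, the step of a 1.5-fold higher number from compound 2 to compound 3 (0.18 log units; within the scatter) lies within the scatter, so the aromatic carbon meta to a large group accepts propyl in place of hydrogen without a measurable loss of binding. Compound 2 and compound 3 cannot be told apart, and the phenyl to 3-propylphenyl change leaves the sub-nanomolar range intact. Nothing available gives a reason for this result. On these data alone, it remains open whether a longer chain such as hexyl, or an amine or carboxylic acid, would be accepted on this carbon. Also open, as far as these compounds go, is whether propyl behaves the same way on the core of compound 1.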